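Compound 4: One Double Bond Drawn the Other Way

This account rests on a few compounds, and the source may have more. Where it says the series, first, only, none or still open, it means among the compounds named here.

Compound 1 `CCN(CC)CCCn1c(=O)/c(=C/c2ccc(O)cc2)s/c1=C1\C(=O)Nc2ccc(Cl)cc21`: 24600 nM
Compound 2 `CCN(CC)CCCn1c(=O)/c(=C/c2ccc(F)cc2F)s/c1=C1/C(=O)Nc2cc(F)ccc21`: 3690 nM
Compound 3 `CN(C)CCn1c(=O)/c(=C/c2ccc(O)cc2)s/c1=C1/C(=O)Nc2ccc(F)cc21`: 1300 nM

In a functional assay on K562 cells (Homo sapiens) for cytotoxicity, read by sulforhodamine B assay, with a stated time of 48 h (a higher number here means a weaker inhibitor, a lower number a stronger inhibitor), compound 2 stands in the middle of the three, with 3690 nM, a higher number than compound 3 gives and a lower one than compound 1 gives. Compound 4 `CCN(CC)CCCn1c(=O)/c(=C/c2ccc(F)cc2F)s/c1=C1\C(=O)Nc2cc(F)ccc21` departs from compound 2 in one way: the two compounds have the same atoms and bonds and differ only in configuration as drawn: 1 of 2 stereo elements differ; a double bond is drawn E in compound 2 and Z in compound 4. Within the data shown here, no measured pair shows such a change alone. Compound 4 is drawn like compound 1 at this double bond, and compound 1 gives 24600 nM, but it differs in other groups too, so it offers only a weak hint of a higher number. The expected result is a small rise, not clearly beyond the scatter, shown by the estimated 1.4-fold higher number from compound 2 to compound 4 (0.13 log units; within the scatter). For compound 4 the estimated value is 5000 nM, with an expected range from 1800 nM to 14000 nM.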

Compound 4, half-maximal inhibitory concentration: 3690 nM
Beside the measured number, compound 4's estimate is 1.4-fold (0.13 log units) above it; the range from low to high includes it.
By their numbers in this assay, from the lowest: compound 3; then compounds 2 and 4 (each within the scatter of the next); then compound 1.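

In this assay, the drawn configuration of this one double bond, taken alone, gives no change at the digits printed from compound 2 to compound 4 (within the scatter). Among these compounds, the earlier compounds could not show this, since each differs from the others in more than one place, and this is the only pair that isolates the change: the fact that compounds 2 and 4 differ only in the configuration as drawn.

The compounds shown leave open whether the double bond would matter as little with a morpholine in place of the diethylamino group, or with a carboxylic acid on the benzylidene ring. They also leave open whether the same holds alongside the groups of compound 1 or compound 3.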